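The compounds below may be only part of what the source reports. "The series", "measured", "known", "first", "only" and "open" are said of these compounds alone.

Three compounds from this series have a solubility number, and a fourth awaits one. Compound 1 `CC(C)Oc1ccc(S(C)(=O)=O)cc1C(=O)N1Cc2cc(C(F)(F)F)cnc2C1` and compound 2 `CC(C)Oc1ccc(S(C)(=O)=O)cc1C(=O)N1Cc2ccc(C3CCOCC3)cc2C1` share the isopropoxy group but differ in their cores; the difference between the two cores is not broken down here. In a physicochemical assay for solubility (on this read-out lower numbers stand for lower solubility and higher numbers for higher solubility), compound 1 gives 114 ug/mL, and compound 2 gives 191 ug/mL, the two lying within the usual scatter of each other. Compound 3 `CS(=O)(=O)c1ccc(OCCC(F)(F)F)c(C(=O)N2Cc3cc(C(F)(F)F)cnc3C2)c1` is compound 1 with one change, (3,3,3-trifluoropropyl in place of isopropyl on an oxygen on an aromatic ring), and in this assay compound 3 gives 513 ug/mL, a step of a 4.5-fold higher number from compound 1 to compound 3 (0.65 log units; beyond the scatter).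

Compound 4 `CS(=O)(=O)c1ccc(OCCC(F)(F)F)c(C(=O)N2Cc3ccc(C4CCOCC4)cc3C2)c1` carries the same change on the core of compound 2: 3,3,3-trifluoropropyl in place of isopropyl on an oxygen on an aromatic ring. Since the surroundings of the changed place are the same in both pairs, the step from compound 2 to compound 4 in this assay is expected to resemble the earlier one, and is estimated at a 3.4-fold higher number from compound 2 to compound 4 (0.53 log units; beyond the scatter), resting on the step seen from compound 1 to compound 3, a 4.5-fold higher number from compound 1 to compound 3 (0.65 log units; beyond the scatter). Compound 4 is therefore estimated to give 650 ug/mL in this assay, most likely between 250 ug/mL and 1500 ug/mL.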

Compound 4, solubility: 334 ug/mL
Compound 4: middle estimate off by 1.9-fold (0.29 log units), on the high side, and the stated range covers the measured number.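

In this assay, the change from isopropoxy to 3,3,3-trifluoropropoxy on the core of compound 2 gives a 1.7-fold higher number from compound 2 to compound 4 (0.24 log units; within the scatter), whereas on the core of compound 1 the same change gave a 4.5-fold higher number from compound 1 to compound 3 (0.65 log units; beyond the scatter). The step beyond the scatter seen on the first core therefore did not carry over as a step beyond the scatter to the second, so the earlier pair alone was not a safe guide to the size of the step on another core. For the compounds shown here, with only one pair on each core, this does not show whether the size of the step truly depends on the core, and nothing given here bears on why the two pairs read as they do.

The compounds shown leave open how the two cores would read with another group in place of isopropoxy, such as a longer chain or a chain ending in an amine or a carboxylic acid. They also leave open whether a third core would follow the pair of compound 1 and compound 3 or the pair of compound 2 and compound 4.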